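Hydroxycarbamoyl arm shortening: notes on four compounds

This account rests on a few compounds, and the source may have more. Where it says the series, first, only, none or still open, it means among the compounds named here.

Measured in a functional assay on NCI-H23 cells (Homo sapiens) for cytotoxicity, read by colorimetric assay; on this read-out higher numbers stand for weaker inhibition and lower numbers for stronger inhibition:
compound 1 `O=C(/C=C/c1ccc(CN2C(=O)/C(=C3\Nc4ccccc4\C3=N/O)c3cccc(Cl)c32)cc1)NO` gives 50 nM
compound 2 `Cc1ccc2c(c1)/C(=C1/Nc3ccccc3/C1=N\O)C(=O)N2Cc1ccc(/C=C/C(=O)NO)cc1` gives 10 nM
compound 3 `Cc1ccc2c(c1)/C(=C1/Nc3ccccc3/C1=N\O)C(=O)N2Cc1ccc(C(=O)NO)cc1` gives 10 nM

Compound 1 stands at the highest number of the three, and the gaps from compound 1 to compound 2 and to compound 3 both lie beyond the usual scatter. Compound 2 and compound 3 sit within the scatter of each other, so no order between them is read. The difference between the core of compound 1 and the core of compound 2 is not broken down here.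

Compound 2 and compound 3 differ in one place only: hydroxycarbamoyl in place of 2-(hydroxycarbamoyl)ethenyl on an aromatic carbon. The step measured for this change is no change at the digits printed from compound 2 to compound 3 (within the scatter).

The same change, at a place described in the same words, turns compound 1 into the unmeasured compound 4 `O=C(NO)c1ccc(CN2C(=O)/C(=C3\Nc4ccccc4\C3=N/O)c3cccc(Cl)c32)cc1`: hydroxycarbamoyl in place of 2-(hydroxycarbamoyl)ethenyl on an aromatic carbon. It is the only structural change that occurs twice among these four compounds, and its one measured occurrence, the pair compound 2 to compound 3, left the number unchanged within the scatter. The expectation for compound 4 therefore rests on one pair alone, on a different core, and carries that uncertainty.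

On that basis the step from compound 1 to compound 4 is expected to be small, no change at the digits printed from compound 1 to compound 4 (within the scatter), because no change at the digits printed from compound 2 to compound 3 (within the scatter). Compound 4 is accordingly estimated at 50 nM in this assay, with a likely range from 20 nM to 125 nM.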

Compound 4, half-maximal inhibitory concentration: 60 nM
Estimate against measurement, compound 4: 1.2-fold (0.08 log units) below; the range from low to high includes it.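

In this assay the change from 2-(hydroxycarbamoyl)ethenyl to hydroxycarbamoyl gives a 1.2-fold higher number from compound 1 to compound 4 (0.08 log units; within the scatter), so the shorter arm leaves the number within the scatter on the core of compound 1 as well. Set beside the earlier pair, the same change reads alike on both cores: the same change on two cores in this assay, no change at the digits printed (within the scatter) from compound 2 to compound 3 and a 1.2-fold higher number (0.08 log units; within the scatter) from compound 1 to compound 4, 1.2-fold (0.08 log units) apart, within the scatter of two such steps. Among the compounds shown here, this shows that the change carried from one core to the other without a step beyond the scatter, but it rests on only two pairs and one cell assay, and it does not show that the step would stay this small on any other core.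

The compounds shown leave open whether the hydroxycarbamoyl group itself is needed and how far the arm can vary, which a carboxylic acid or a primary amide in its place, or a longer chain ending in hydroxycarbamoyl, would address. For the compounds shown here, the difference between the core of compound 1 and the core of compound 2 also stays unassigned, as no pair here alters a single feature of the core.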